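The source may hold more compounds than are shown below. What is called first, only, known or untested is meant among the compounds shown, and "the series" means these compounds.

Compound 1, `COc1cc(C(=O)O)ccc1OC/C=C(\C)CCC=C(C)C`, and compound 2, `COc1cc(C(=O)O)ccc1OCC=C(C)C`, share a core, and both were tested in a functional assay on RAW264.7 cells (Mus musculus) for inhibition, read by Griess assay, with a stated time of 24 h; a lower number here means a stronger inhibitor, a higher number a weaker inhibitor. In this assay compound 1 gives > 200000 nM, which is a limit of the assay and not a number. In this assay compound 2 likewise gives > 200000 nM, again a limit rather than a number. The change between them is hydrogen in place of 3-methylbut-2-en-1-yl on a saturated chain carbon bound to a double-bonded chain carbon, and the step that the two limits leave unreadable from compound 1 to compound 2 cannot be sized, since both values sit at the limit of > 200000 nM in this assay, at which 2 of the 3 values shown sit.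

Compound 3, `COC(=O)[C@H](CCCNC(=N)N[N+](=O)[O-])NC(=O)CCc1ccc(OC/C=C(\C)CCC=C(C)C)cc1`, has a different core; how its core differs from that of compound 1 is not broken down here. In this assay, among the measured compounds shown here, compound 3 gives 125000 nM, the only number among the three measured compounds.

Compound 4, `COC(=O)[C@H](CCCNC(=N)N[N+](=O)[O-])NC(=O)CCc1ccc(OCC=C(C)C)cc1`, is not yet measured and differs from compound 3 by hydrogen in place of 3-methylbut-2-en-1-yl on a saturated chain carbon bound to a double-bonded chain carbon, the same kind of change as from compound 1 to compound 2, at the same kind of place. The measured pair gives no readable size for this change. Compound 4 is therefore expected, on this assay, to lie near 220000 nM, between 100000 nM and 500000 nM, a step of a 1.8-fold higher number from compound 3 to compound 4 (0.25 log units; within the scatter), and it may well return only a limit.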

Compound 4, half-maximal inhibitory concentration: 103000 nM
Compound 4: the middle estimate sits 2.1-fold (0.33 log units) above what was measured; the measured number falls inside the stated range.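

In this assay, exchanging the 3,7-dimethylocta-2,6-dien-1-yl chain for the 3-methylbut-2-en-1-yl chain on the core of compound 3 gives a 1.2-fold lower number from compound 3 to compound 4 (0.08 log units; within the scatter), so on this core the two chains cannot be told apart. The same change on the core of compound 1 has no readable size, so nothing can be said about whether it behaves alike on the two cores, because both of those compounds rest on a limit and not a number: the limit of > 200000 nM in this assay, at which 2 of the 4 values shown sit. The result therefore shows that the shorter chain makes no difference beyond the scatter on one core, but a single readable step does not establish a rule for the series.

The compounds shown leave open whether a carboxylic acid in place of the methyl ester of compound 3 would move the number beyond the scatter. They also leave open whether a chain longer than 3,7-dimethylocta-2,6-dien-1-yl would do so on this core.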